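The source may report more compounds than this note shows. Statements on the series, on what has been measured and on what is new or still open speak of the compounds shown alone.

Compound 1 `C=C[C@@](C)(/C=C/c1ccc(O)c(/C=C/c2ccc(F)cc2)c1)CCC=C(C)C` opens the set. In an ADME assay on BJ cells (Homo sapiens) for cytotoxicity, with a stated time of 72 h (a higher number here means that more compound is needed for the effect, a lower number that less compound is needed), compound 1 gives > 36600 nM, a limit of the assay. Compound 2 `C=C[C@@](C)(/C=C/c1ccc(O)c(/C=C/c2ccc(Cl)cc2)c1)CCC=C(C)C` differs from compound 1 by chloro in place of fluoro on an aromatic carbon. In this assay compound 2 gives > 36600 nM, again a limit. The step that the two limits leave unreadable from compound 1 to compound 2 is therefore not readable; both values sit at the limit of > 36600 nM in this assay, at which 3 of the 3 values shown sit. Compound 3 `CC(C)=CCC[C@](C)(/C=C/c1ccc(O)cc1)/C=C/c1cccc(F)c1` rests on another core; the difference between the two cores is not broken down here. In this assay compound 3 gives > 36600 nM, also a limit. Compound 4 `CC(C)=CCC[C@](C)(/C=C/c1ccc(O)cc1)/C=C/c1cccc(Cl)c1` differs from compound 3 by chloro in place of fluoro on an aromatic carbon; this is the same kind of change as from compound 1 to compound 2, yet there the place is para to a large group and here it is meta to a large group. For compound 4 a step that the limit leaves unreadable from compound 3 to compound 4 is expected, resting on (the limit of > 36600 nM in this assay, at which 3 of the 3 values shown sit), at which compound 3 sits. Compound 4 is estimated at 50000 nM, most probably reported only as a limit once more.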

Compound 4, half-maximal effective concentration: > 36600 nM
Compound 4 gave a limit, no number; the forecaster's own chance of this, stated with the estimate: 90%; the middle value is on the limit's open side.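

No step can be read from compound 3 to compound 4, since both values are limits of the assay: the limit of > 36600 nM in this assay, at which 4 of the 4 values shown sit. The compounds shown leave open what chloro in place of fluoro does to the actual value in this assay.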